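The source may report more compounds than this note shows. Statements on the series, on what has been measured and on what is new or still open speak of the compounds shown alone.

Measured so far in a functional assay on IGROV-1 cells (Homo sapiens) for inhibition, read by sulforhodamine B assay, with a stated time of 48 h; on this read-out lower numbers stand for stronger inhibition of growth and higher numbers for weaker inhibition of growth:
- compound 1 `COc1ccc(CNc2nc3cc(N)cc(N)c3nc2-c2ccccc2)cc1OC`: 40700 nM
- compound 2 `Nc1cc(N)c2nc(-c3ccccc3)c(NCc3ccc(F)cc3)nc2c1`: only a limit, < 100000 nM

In this assay compound 1 gives 40700 nM. For compound 2 the read-out is a limit, < 100000 nM, not a number. The one step between measured compounds, a step that the limit leaves unreadable from compound 1 to compound 2, is therefore unreadable because of the limit of < 100000 nM in this assay, at which 1 of the 2 values shown sits, and compound 2 stands only as a limit on the numbers shown.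

Compound 3 `Nc1cc(N)c2nc(-c3ccccc3)c(Sc3ccc(Cl)c(Cl)c3)nc2c1` differs from compound 2 by (3,4-dichlorophenyl)sulfanyl in place of (4-fluorobenzyl)amino on an aromatic carbon. For the measured compounds named here, no measured step bears on this change directly; the single step is unreadable, so no size or direction can be taken from it. The estimate for compound 3 rests only on the range spanned by compound 1 and the limit of compound 2.

Compound 3 is expected to give about 35000 nM, between 8000 nM and 100000 nM. The step that the limit leaves unreadable from compound 2 to compound 3 is thus an expectation only, with a real chance that the assay again reports a limit.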

Compound 3, concentration for total growth inhibition: 27500 nM
The estimate for compound 3 lay 1.3-fold (0.10 log units) above the measured number; the range from low to high includes it.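

In this assay compound 2 stands only as a limit, so no step to compound 3 can be read: the limit of < 100000 nM in this assay, at which 1 of the 3 values shown sits.

The compounds shown leave open the size and direction of the change from (4-fluorobenzyl)amino to (3,4-dichlorophenyl)sulfanyl on the shared core.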